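The source may report more compounds than this note shows. Statements on the series, on what has been measured and on what is new or still open speak of the compounds shown alone.

compound 1 `CC(=O)c1ccc(NC(=O)Cn2nc(-c3ccc(Cl)cc3)nc2N)cc1`: 7.32%
compound 2 `C/C(=N\O)c1ccc(NC(=O)Cn2nc(-c3ccc(Cl)cc3)nc2N)cc1`: 18.3%
compound 3 `C/C(=N/O)c1ccc(NC(=O)Cn2nc(C(F)(F)F)nc2N)cc1`: 16%

These values come from a functional assay on SR cells (Homo sapiens) for inhibition, read by sulforhodamine B assay, with a stated time of 48 h, tested at 10 uM; a higher number here means more inhibition of growth at the concentration tested, a lower number less inhibition of growth. Compound 3 lies within the scatter of both compound 1 and compound 2. Compound 4 `C/C(=N/O)c1ccc(NC(=O)Cn2nc(-c3ccccc3)nc2N)cc1` carries phenyl in place of trifluoromethyl on an aromatic carbon.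

Going by the values given here, the only measured step, a number 11 percentage points higher from compound 1 to compound 2 (beyond the scatter), is modest and changes a different place, so it says little here. The nearest guide is a comparison at this carbon. Compound 2, with a chlorophenyl group there, gives 18.3%, and compound 3, with trifluoromethyl, gives 16%, which is within the scatter, although their oximes are drawn differently. The expected change is a number 1 percentage points higher from compound 3 to compound 4 (within the scatter), so no step beyond the scatter is expected. Compound 4 is estimated at 17%, with an expected range of 6% to 30%.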

Compound 4, percent growth inhibition at one concentration: 5.58%
The estimate for compound 4 lay 11.4 percentage points above the measured number, outside the stated range (below it).
By their numbers in this assay, from the lowest: compounds 4, 1, 3 and 2 (each within the scatter of the next, the first and the last beyond it).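

In this assay phenyl in place of trifluoromethyl gives a number 10.4 percentage points lower from compound 3 to compound 4 (beyond the scatter) and so shows that the group on this aromatic carbon can change growth inhibition, if only modestly. Going by these compounds alone, this is the first comparison at this carbon with the rest of the molecule unchanged, since compound 2 and compound 3 also differ in how their oximes are drawn. No measurement here accounts for the step.

From the compounds shown here alone, how an amine, a carboxylic acid or a longer chain on this carbon would behave stays open. So does the effect of the chlorine on phenyl, since compound 2 and compound 4 also differ in their oximes.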